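This account rests on a few compounds, and the source may have more. Where it says the series, first, only, none or still open, it means among the compounds named here.

Measured so far in an assay on isolated protein for inhibition of protein kinase C delta type (Homo sapiens), read by TR-FRET, with a stated time of 2 h; on this read-out lower numbers stand for stronger inhibition and higher numbers for weaker inhibition:

Compound 1, `N#Cc1cnc(NCc2cnccc2C(F)(F)F)cc1NC[C@H]1CC[C@@H](O)CC1`, gives 500 nM.
Compound 2, `CO[C@H]1CC[C@@H](CNc2cc(NCc3cnccc3C(F)(F)F)ncc2C#N)CC1`, gives 5000 nM.
Compound 3, `CN(C)C(=O)[C@H]1CC[C@@H](Nc2cc(NCc3cnccc3C(F)(F)F)ncc2C#N)CC1`, gives 1800 nM.

Compound 2 stands highest of the three numbers in this assay; its nearest neighbour is compound 3 and its furthest is compound 1. Compound 4, `CC1(C)C[C@@H](Nc2cc(NCc3cnccc3C(F)(F)F)ncc2C#N)CC[C@@H]1O`, has not yet been measured. It differs from compound 2 by 4-hydroxy-3,3-dimethylcyclohexyl in place of (4-methoxycyclohexyl)methyl on a nitrogen on an aromatic ring. For the measured compounds named here, the one measured step that bears on this change is a 10-fold higher number from compound 1 to compound 2 (1.00 log units; beyond the scatter), where the free hydroxyl of compound 1 was turned into a methyl ether. Compound 4 removes that methyl again and restores a free hydroxyl, so the step from compound 2 to compound 4 is expected to run downward. Going by the values given here, the change also places the ring on the nitrogen without the intervening methylene, as in compound 3, and brings in the 3,3-dimethyl substitution, for which no measured step exists; compound 3 itself gives a number lower than compound 2 but higher than compound 1. Compound 4 is therefore expected to fall between those two, with an estimated 6.3-fold lower number from compound 2 to compound 4 (0.80 log units; beyond the scatter), that is an expected 800 nM in this assay, ranging from 250 nM to 2500 nM.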

Compound 4, half-maximal inhibitory concentration: 2400 nM
The estimate for compound 4 lay 3.0-fold (0.48 log units) below the measured number; measured number inside the range.
By their numbers in this assay, from the lowest: compound 1; then compounds 3 and 4 (each within the scatter of the next); then compound 2.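

In this assay, restoring a free hydroxyl did not by itself recover the lost ground: replacing (4-methoxycyclohexyl)methyl with 4-hydroxy-3,3-dimethylcyclohexyl on a nitrogen on an aromatic ring gave a 2.1-fold lower number from compound 2 to compound 4 (0.32 log units; beyond the scatter) and so was smaller than the reverse of the earlier step, a 10-fold higher number from compound 1 to compound 2 (1.00 log units; beyond the scatter). Compared with compound 1, which also carries a free hydroxyl, the same group in place of (4-hydroxycyclohexyl)methyl gave a 4.8-fold higher number from compound 1 to compound 4 (0.68 log units; beyond the scatter), showing that at this nitrogen a hydroxyl on a cyclohexane ring does not alone set the number. This single swap combines the loss of the methylene with the arrival of the two ring methyl groups, and nothing available here explains either step.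

The compounds shown do not separate those two alterations, leaving open how much of the step from compound 1 belongs to each, since none pairs a hydroxycyclohexyl group bound directly to the nitrogen with an unsubstituted ring. Also open, from the compounds shown here alone, is how this position would respond to a primary amine or a carboxylic acid in place of the hydroxyl.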